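This account rests on a few compounds, and the source may have more. Where it says the series, first, only, none or still open, it means among the compounds named here.

The numbers below come from an assay on CHO-K1 cells for antagonist activity at adenosine receptor A1 (Homo sapiens), read by a beta-galactosidase reporter, with stated times of 15 min and 6 h; a lower number here means a stronger inhibitor, a higher number a weaker inhibitor.

Compound 1, `CN(C)Cc1cc2c(N)nc(-c3ccco3)nc2s1`, gives 3550 nM.
Compound 2, `Nc1nc(-c2ccco2)nc2sc(CN3CCCC3)cc12`, gives 6430 nM.
Compound 3, `Nc1nc(-c2ccco2)nc2sc(CN3CC=CCC3)cc12`, gives 150 nM.

Compound 3 has the lowest number of the three. The step of a 24-fold lower number from compound 1 to compound 3 (1.37 log units; beyond the scatter) and the step of a 43-fold lower number from compound 2 to compound 3 (1.63 log units; beyond the scatter) both set compound 3 well apart, while the step of a 1.8-fold higher number from compound 1 to compound 2 (0.26 log units; within the scatter) leaves compound 1 and compound 2 within the scatter of each other. All three share the same core and differ only in the amine group carried on a saturated chain carbon bound to an aromatic carbon.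

Compound 4, `Nc1nc(-c2ccco2)nc2sc(CN3CCC(O)CC3)cc12`, has not yet been measured. Compared with compound 3 the change is a group of 7 heavy atoms (5 carbon, 1 nitrogen, 1 oxygen; one six-membered non-aromatic ring with 1 hetero atom) in place of a group of 6 heavy atoms (5 carbon, 1 nitrogen; one six-membered non-aromatic ring with 1 hetero atom), on a saturated chain carbon bound to an aromatic carbon. Of the measured steps, a 24-fold lower number from compound 1 to compound 3 (1.37 log units; beyond the scatter) and a 43-fold lower number from compound 2 to compound 3 (1.63 log units; beyond the scatter) bear on it most closely: they show that the six-membered ring of compound 3 goes with a much lower number than either smaller group. For the measured compounds named here, no measured pair tells what happens when a hydroxyl enters and the double bond leaves while the ring size is kept, so the direction is uncertain. For compound 4 the expected step is a 5.3-fold higher number from compound 3 to compound 4 (0.73 log units; beyond the scatter), a somewhat higher number. Compound 4 is therefore expected to give about 800 nM, with a range from 150 nM to 5000 nM.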

Compound 4, inhibition constant: 4000 nM
For compound 4 the middle estimate is 5.0-fold (0.70 log units) below the measured one; the measured number falls inside the stated range.
By their numbers in this assay, from the lowest: compound 3; then compounds 1, 4 and 2 (each within the scatter of the next).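

In this assay, a six-membered ring at this place is not enough to keep the number low: putting 4-hydroxypiperidin-1-yl on the saturated chain carbon gives a 27-fold higher number from compound 3 to compound 4 (1.43 log units; beyond the scatter), even though the ring size stays the same. The comparisons with the two smaller groups show a 1.6-fold lower number from compound 2 to compound 4 (0.21 log units; within the scatter) and a 1.1-fold higher number from compound 1 to compound 4 (0.05 log units; within the scatter), so compound 4 cannot be told apart from the pyrrolidin-1-yl and dimethylamino compounds, and only compound 3 stands apart among the four. Any rule that a six-membered ring here goes with a low number therefore fails, with compound 4 as the compound against it, and the low number belongs to the particular ring of compound 3 rather than to ring size alone.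

This single change both adds a hydroxyl and removes the ring double bond, so these compounds cannot separate the two, and a plain piperidin-1-yl group, with neither feature, would be the natural comparison. Nothing given here explains why the number rises so sharply with this change.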